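Nitro removed: from compound 1 to compound 4

A few compounds are considered here, and "the series" means these few. Any claim that something is new, unique, unknown or untested is made for them only; others in the source may bear on it.

The series shares one core and varies the six-membered aromatic ring attached to an aromatic nitrogen. Compound 1 `C/C(=C\CC/C(C)=C/CC[C@@H]1[C@@]2(C)CCC(=O)C(C)(C)[C@H]2CC[C@@]1(C)O)CC/C=C(\C)C(=O)OCc1cn(-c2ccc([N+](=O)[O-])cc2)nn1` carries 4-nitrophenyl there. In a functional assay on DU-145 cells (Homo sapiens) for antiproliferative activity, read by MTT assay, with a stated time of 48 h (a higher number here means a weaker inhibitor, a lower number a stronger inhibitor), compound 1 returns only the assay limit, > 150000 nM, not a number. Compound 2 `C/C(=C\CC/C(C)=C/CC[C@@H]1[C@@]2(C)CCC(=O)C(C)(C)[C@H]2CC[C@@]1(C)O)CC/C=C(\C)C(=O)OCc1cn(-c2ccccc2C)nn1`, with 2-methylphenyl in place of 4-nitrophenyl on an aromatic nitrogen, likewise sits at the limit, giving > 150000 nM in this assay. Among the compounds with values here, compound 3 `C/C(=C\CC/C(C)=C/CC[C@@H]1[C@@]2(C)CCC(=O)C(C)(C)[C@H]2CC[C@@]1(C)O)CC/C=C(\C)C(=O)OCc1cn(-c2cccc(Cl)c2)nn1`, with 3-chlorophenyl, is the only member with a number, 103000 nM in this assay. The step of an at least 1.4-fold lower number from compound 1 to compound 3 (0.16 log units; that floor lies within the scatter) and the step of an at least 1.4-fold lower number from compound 2 to compound 3 (0.16 log units; that floor lies within the scatter) both rest on a floor within the scatter, and a step that the two limits leave unreadable from compound 1 to compound 2 cannot be read; the limit of > 150000 nM in this assay, at which 2 of the 3 values shown sit, marks where compound 1 stands. Compound 4 `C/C(=C\CC/C(C)=C/CC[C@@H]1[C@@]2(C)CCC(=O)C(C)(C)[C@H]2CC[C@@]1(C)O)CC/C=C(\C)C(=O)OCc1cn(-c2ccccc2)nn1` differs from compound 1 by hydrogen in place of nitro on an aromatic carbon. Within the data shown here, no measured step removes a group from that ring; all measured changes swap one substituted ring for another, and every value stays high. Compound 4 is expected near the limit as well, with an estimated step of a number no higher from compound 1 to compound 4 (the limit leaves the size open) that lies within the scatter. The estimate for compound 4 is 150000 nM, in a range from 70000 nM to 300000 nM, with a good chance that only a limit is reported.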

Compound 4, half-maximal inhibitory concentration: 95500 nM
Beside the measured number, compound 4's estimate is 1.6-fold (0.20 log units) above it; low and high end bracket the measured number.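

In this assay, hydrogen in place of chloro gives a 1.1-fold lower number from compound 3 to compound 4 (0.03 log units; within the scatter), so the bare phenyl ring of compound 4 cannot be told apart from the chlorinated ring of compound 3. Hydrogen in place of nitro gives an at least 1.5-fold lower number from compound 1 to compound 4 (0.19 log units; that floor lies within the scatter), and hydrogen in place of methyl gives an at least 1.5-fold lower number from compound 2 to compound 4 (0.19 log units; that floor lies within the scatter); both floors stay within the scatter, so neither step establishes a real gain from losing the substituent. Compound 4 adds an unsubstituted reference with a readable number, while the upper end of the series remains a limit, not a number: the limit of > 150000 nM in this assay, at which 2 of the 4 values shown sit.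

Going by these compounds, whether an amine or a carboxylic acid on this ring would move the value beyond the scatter stays open. Also open, on these data alone, is how far a longer chain in place of the ring would change these high values.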